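Imidazole to triazole on the indole-bearing aryl ring

The compounds below may be only part of what the source reports. "The series", "measured", "known", "first", "only" and "open" are said of these compounds alone.

Measured so far:
compound 1 `OC[C@H](NC1CCN(CCCc2c[nH]c3ccc(-n4ccnc4)cc23)CC1)c1ccccc1` gives 74%
compound 2 `c1cc(CNC2CCN(CCCc3c[nH]c4ccc(-n5cnnc5)cc34)CC2)co1` gives 65%

Of the compounds shown here, two have been measured in a functional assay on CHO cells for activation of 5-hydroxytryptamine receptor 1D (Homo sapiens), read by GTPgammaS binding; a higher number here means a larger maximal response, a lower number a smaller maximal response. Compound 1 `OC[C@H](NC1CCN(CCCc2c[nH]c3ccc(-n4ccnc4)cc23)CC1)c1ccccc1` gives 74% and holds the higher of the two numbers, while compound 2 `c1cc(CNC2CCN(CCCc3c[nH]c4ccc(-n5cnnc5)cc34)CC2)co1` gives 65%; the gap between these two values lies within the usual scatter of the assay, so no order between them can be claimed.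

Compound 3 `OC[C@H](NC1CCN(CCCc2c[nH]c3ccc(-n4cncn4)cc23)CC1)c1ccccc1` has not yet been measured. It differs from compound 1 in one place: 1H-1,2,4-triazol-1-yl in place of 1H-imidazol-1-yl on an aromatic carbon. Going by the values given here, no step between measured compounds tests this exact change, so the expectation rests only on the two numbers above. Because compound 1 gives 74% and compound 2, carrying a different five-membered ring at the same position, gives 65%, a change no larger than the scatter is expected, with the step of a number 6 percentage points lower from compound 1 to compound 3 (within the scatter) pointing slightly downward if anywhere. Compound 3 is therefore estimated at 68%, with a range from 50% to 85%.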

Compound 3, largest response reached (reported as efficacy), in percent of the reference or control that the assay uses: 77%
The estimate for compound 3 lay 9 percentage points below the measured number; the range from low to high includes it.
By their numbers in this assay, from the lowest: compounds 2, 1 and 3 (each within the scatter of the next, the first and the last beyond it).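

In this assay, placing 1H-1,2,4-triazol-1-yl instead of 1H-imidazol-1-yl on the same aromatic carbon gives a number 3 percentage points higher from compound 1 to compound 3 (within the scatter). Going by these compounds alone, this is the first direct test of the change, with the rest of the molecule held constant. At this position, exchanging one ring carbon for a nitrogen and adding a hydrogen-bond acceptor therefore leaves no difference in maximal response that can be told from the scatter. No accompanying measurement offers an explanation for this result.

The compounds shown leave open whether this position would accept a group other than a five-membered aromatic ring, such as a nitrile or an amide. They also leave open whether the same exchange would give a similar result with a different amine side chain.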